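Ethyl carbamate to free aniline on a thiazole hydroxamate

This account rests on a few compounds, and the source may have more. Where it says the series, first, only, none or still open, it means among the compounds named here.

Compound 3 `CCOC(=O)Nc1cccc(-c2csc(NC(=O)CCCCCC(=O)NO)n2)c1` carries an ethoxycarbonylamino group on the phenyl ring and a hydroxamic acid at the far end of the chain. In an assay on isolated protein for inhibition of histone deacetylase 8 (Homo sapiens), read by fluorescence, with a stated time of 17 h (a lower number here means a stronger inhibitor, a higher number a weaker inhibitor), compound 3 gives 787 nM, the lowest of the two numbers measured; its nearest neighbour is compound 2 `CC(C)(C)OC(=O)Nc1cccc(-c2csc(NC(=O)CCCCCC(=O)NO)n2)c1`, which in this assay gives 2580 nM. For the measured compounds named here, the step of a 3.3-fold lower number from compound 2 to compound 3 (0.52 log units; beyond the scatter) is the only measured step that involves the group on the aniline nitrogen. Compound 1 `Nc1cccc(-c2csc(NC(=O)CCCCCC(=O)Nc3ccccc3N)n2)c1` differs in the zinc-binding end as well as in the aniline group; in this assay compound 1 gives > 30000 nM, which is a limit of the assay and not a number (the limit of > 30000 nM in this assay, at which 1 of the 3 values shown sits).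

Compound 4 `Nc1cccc(-c2csc(NC(=O)CCCCCC(=O)NO)n2)c1` is the compound not yet measured. Its difference from compound 3 is hydrogen in place of ethoxycarbonyl on a nitrogen on an aromatic ring. The measured step from compound 2 to compound 3 went toward a lower number as the carbamate ester became smaller; compound 4 removes the carbamate altogether, a larger change than any measured one, so the expected step is at most modest. The estimated step of a 1.1-fold lower number from compound 3 to compound 4 (0.05 log units; within the scatter) is taken as within the scatter. Compound 4 is expected to give about 700 nM in this assay, between 200 nM and 2500 nM.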

Compound 4, half-maximal inhibitory concentration: 1950 nM
For compound 4 the middle estimate is 2.8-fold (0.44 log units) below the measured one, and the stated range covers the measured number.
By their numbers in this assay, from the lowest: compound 3; then compounds 4 and 2 (each within the scatter of the next). At a limit, above all of these: compound 1.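

In this assay, taking off the ethoxycarbonyl gives a 2.5-fold higher number from compound 3 to compound 4 (0.39 log units; beyond the scatter), so the lower number that came with the smaller carbamate ester does not carry through to the free amino group, and compound 4 goes against any reading that less on this nitrogen gives a lower number. Replacing tert-butoxycarbonyl with hydrogen gives a 1.3-fold lower number from compound 2 to compound 4 (0.12 log units; within the scatter), so these two compounds are not told apart, and among the three hydroxamic acids only the ethyl carbamate of compound 3 stands clear of the others. With the free amino group kept on the phenyl ring, hydroxy in place of 2-aminophenyl on the amide-type nitrogen gives an at least 15-fold lower number from compound 1 to compound 4 (1.18 log units; beyond the scatter), a step that rests on a limit of the assay for compound 1: the limit of > 30000 nM in this assay, at which 1 of the 4 values shown sits.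

What the compounds shown leave open is whether the lower number of compound 3 depends on the carbamate oxygen or on the size of the ester, which a methyl carbamate, a propyl carbamate or an acetyl group on the same nitrogen would help to settle. They also leave open how the carbamates would read with the 2-aminophenyl amide end in place of the hydroxamic acid.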